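Nitrophenyl isomers: from 3-nitrophenyl to 4-nitrophenyl

The source may hold more compounds than are shown below. What is called first, only, known or untested is meant among the compounds shown, and "the series" means these compounds.

Compound 1 `COc1cc(C(=O)c2cn(-c3cccc(C)c3)cc2-c2ccccc2[N+](=O)[O-])cc(OC)c1OC` gives 220 nM
Compound 2 `COc1cc(C(=O)c2cn(-c3cccc(C)c3)cc2-c2cccc([N+](=O)[O-])c2)cc(OC)c1OC` gives 880 nM

For the measured compounds named here, in a functional assay on MCF7 cells (Homo sapiens) for cytotoxicity, read by MTT assay, with a stated time of 96 h (on this read-out higher numbers stand for weaker inhibition and lower numbers for stronger inhibition), compound 2 stands at 880 nM as the highest of the two numbers so far, and compound 1 is its only neighbour. Next comes compound 3 `COc1cc(C(=O)c2cn(-c3cccc(C)c3)cc2-c2ccc([N+](=O)[O-])cc2)cc(OC)c1OC` with 4-nitrophenyl in place of 3-nitrophenyl on an aromatic carbon, counted as 4-nitrophenyl in place of 3-nitrophenyl on an aromatic carbon and leaving the rest of the molecule unchanged. Going by the values given here, one measured step bears on this change, namely a 4.0-fold higher number from compound 1 to compound 2 (0.60 log units; beyond the scatter) for 3-nitrophenyl in place of 2-nitrophenyl, which is modest but beyond the scatter. That single step shows that the choice among nitrophenyl isomers can move the number, but it sets no direction for a further isomer. A step no larger than that one is expected, in either direction, and quite possibly none beyond the scatter. The expected step is a 1.0-fold higher number from compound 2 to compound 3 (0.01 log units; within the scatter) in this assay with wide uncertainty. For compound 3 the estimated value is 900 nM with an expected range from 300 nM to 2700 nM on present evidence.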

Compound 3, half-maximal inhibitory concentration: 780 nM
Estimate against measurement, compound 3: 1.2-fold (0.06 log units) above; the range from low to high includes it.
By their numbers in this assay, from the lowest: compound 1; then compounds 3 and 2 (each within the scatter of the next).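

In this assay, 4-nitrophenyl in place of 3-nitrophenyl gives a 1.1-fold lower number from compound 2 to compound 3 (0.05 log units; within the scatter) and so leaves these two isomers indistinguishable on this read-out. With 4-nitrophenyl in place of 2-nitrophenyl, the series shows a 3.5-fold higher number from compound 1 to compound 3 (0.55 log units; beyond the scatter) and the picture at this aromatic carbon is now complete for the three nitrophenyl isomers on the shared core: compound 1 is the most potent of the three, with its steps to both others beyond the scatter, while compound 2 and compound 3 form a single level. The separation therefore belongs to 2-nitrophenyl alone rather than to a gradual trend across the isomers, and nothing at hand accounts for it.

Still open, going by these compounds, is whether the advantage of compound 1 depends on the nitro group itself or would persist with another group, such as an amine or a carboxylic acid, in its place on the phenyl ring. Also open, on these data alone, is whether the same separation among the isomers would hold with a group other than 3-methylphenyl on the ring nitrogen.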